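This account rests on a few compounds, and the source may have more. Where it says the series, first, only, none or still open, it means among the compounds named here.

Compound 1 `O=C(Nc1ccc(Nc2nccc(NC3CCCC3)n2)cc1)Nc1ccc(Cl)c(C(F)(F)F)c1` is the reference point here. Among the compounds with values here, in a functional assay on HCT-116 cells (Homo sapiens) for antiproliferative activity, read by MTT assay, with a stated time of 72 h (on this read-out lower numbers stand for stronger inhibition and higher numbers for weaker inhibition), compound 1 gives 2510 nM, the lowest of the three numbers so far. Compound 2 `O=C(Nc1ccc(Nc2nccc(NC3CC3)n2)cc1)Nc1ccc(Cl)c(C(F)(F)F)c1` gives 16400 nM in this assay, and compound 3 `CCCNc1ccnc(Nc2ccc(NC(=O)Nc3ccc(Cl)c(C(F)(F)F)c3)cc2)n1` gives 4240 nM in this assay. Of the two changes made at the nitrogen on the aromatic ring, a 6.5-fold higher number from compound 1 to compound 2 (0.82 log units; beyond the scatter) lies beyond the scatter, whereas a 1.7-fold higher number from compound 1 to compound 3 (0.23 log units; within the scatter) stays within it. Compound 4 `Cn1cc(Nc2ccnc(Nc3ccc(NC(=O)Nc4ccc(Cl)c(C(F)(F)F)c4)cc3)n2)cn1` carries the change (1-methyl-1H-pyrazol-4-yl in place of cyclopentyl on a nitrogen on an aromatic ring). Within the data shown here, no measured step replaces the saturated ring with an aromatic one, so the expectation rests only on the mixed outcome of those two earlier steps. Compound 4 is therefore expected to show a 1.2-fold higher number from compound 1 to compound 4 (0.08 log units; within the scatter), a step within the scatter. The estimate for compound 4 is 3000 nM, in the range 800 nM to 12000 nM.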

Compound 4, half-maximal inhibitory concentration: 4850 nM
Compound 4: the middle estimate sits 1.6-fold (0.21 log units) below what was measured; the measured number falls inside the stated range.
By their numbers in this assay, from the lowest: compounds 1, 3 and 4 (each within the scatter of the next); then compound 2.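

At the nitrogen on the aromatic ring, an aromatic ring with 2 hetero atoms is accepted in this assay without leaving the range of the saturated and open-chain groups: a 1.9-fold higher number from compound 1 to compound 4 (0.29 log units; within the scatter) and a 1.1-fold higher number from compound 3 to compound 4 (0.06 log units; within the scatter) both stay within the scatter. Only cyclopropyl stands apart, with a 3.4-fold lower number from compound 2 to compound 4 (0.53 log units; beyond the scatter) beyond the scatter. Nothing available accounts for these numbers. As far as these compounds go, whether an unsubstituted phenyl ring or a chain ending in an amine, such as 2-(dimethylamino)ethyl, would fit this pattern remains open.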